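A few compounds are considered here, and "the series" means these few. Any claim that something is new, unique, unknown or untested is made for them only; others in the source may bear on it.

Series notes, growth inhibition in a functional assay on COLO 205 cells (Homo sapiens) for inhibition, read by sulforhodamine B assay, with a stated time of 48 h, tested at 50 uM; a higher number here means more inhibition of growth at the concentration tested, a lower number less inhibition of growth:

compound 1 `COc1ccc(/C=C/C(=O)/C=C/c2ccc(OCc3cn(CCCCCOc4cc(=O)oc5ccccc45)nn3)c(OC)c2)cc1OC` gives 43%
compound 2 `COc1cccc(/C=C/C(=O)/C=C/c2ccc(OCc3cn(CCCCCOc4cc(=O)oc5ccccc45)nn3)c(OC)c2)c1` gives 34%
compound 3 `COc1cccc(/C=C/C(=O)/C=C/c2ccc(OCc3cn(CCCOc4cc(=O)oc5ccccc45)nn3)c(OC)c2)c1` gives 52%

Compounds 1 and 2 share one core and differ by methoxy in place of hydrogen on an aromatic carbon; this gives a number 9 percentage points higher from compound 2 to compound 1 (within the scatter), so in this assay the two read as equal within the usual scatter. Compound 3 carries a shorter chain between the triazole and the coumarin; the difference between its core and that of compound 2 is not broken down here. Compound 3 shows the highest number of the three, and its distance to compound 2 lies beyond the scatter, while its distance to compound 1 does not.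

Compound 4 `COc1ccc(/C=C/C(=O)/C=C/c2ccc(OCc3cn(CCCOc4cc(=O)oc5ccccc45)nn3)c(OC)c2)cc1OC` is the partner of compound 3 in the same way compound 1 is to compound 2: the change is methoxy in place of hydrogen on an aromatic carbon, the same change in both pairs. In this assay, within the data shown here, the step from compound 3 to compound 4 is expected to be small, a number 6 percentage points higher from compound 3 to compound 4 (within the scatter), because the only measured instance, a number 9 percentage points higher from compound 2 to compound 1 (within the scatter), stayed within the scatter. Compound 4 is therefore expected at about 58%, with the range 45% to 71%.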

Compound 4, percent growth inhibition at one concentration: 65%
Compound 4: the middle estimate sits 7 percentage points below what was measured, and the stated range covers the measured number.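

In this assay, methoxy in place of hydrogen on an aromatic carbon, here 3-methoxyphenyl to 3,4-dimethoxyphenyl, gives a number 13 percentage points higher from compound 3 to compound 4 (beyond the scatter). The steps on the two cores cannot be told apart in size: the same change on two cores in this assay, a number 9 percentage points higher (within the scatter) from compound 2 to compound 1 and a number 13 percentage points higher (beyond the scatter) from compound 3 to compound 4, 4 percentage points apart, within the scatter of two such steps. Among these compounds, this shows that the change carries across these two cores, which differ in the chain between the triazole and the coumarin, without a measurable difference in step size; it does not show a firm gain on both cores, since only one of the two steps lies beyond the scatter, and two pairs do not establish that the step holds across the wider series.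

Still open, from the compounds shown here alone, is whether a hydroxy group, a fluorine atom or an amine at that aromatic carbon would read like methoxy. Also open, going by these compounds, is whether the step holds with a chain longer than that of compound 1 between the triazole and the coumarin.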